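Ring swap on the aromatic nitrogen: compound 2 to compound 4

This account rests on a few compounds, and the source may have more. Where it says the series, first, only, none or still open, it means among the compounds named here.

Measured so far in a functional assay on HCT-116 cells (Homo sapiens) for inhibition, read by MTT assay, with a stated time of 72 h; a higher number here means a weaker inhibitor of growth, a lower number a stronger inhibitor of growth:
compound 1, `N#Cc1ccc(Cn2cc(C[C@H](O)COCCOC[C@@H](O)Cc3ccc(-c4ccccc4)cc3)nn2)cc1`, 8800 nM
compound 2, `O[C@H](COCCOC[C@@H](O)Cc1cn(-c2cccs2)nn1)Cc1ccc(-c2ccccc2)cc1`, 33400 nM
compound 3, `COC1=C(C)C(=O)C(CCCCCCCCCCn2cc(C[C@H](O)COCCOC[C@@H](O)Cc3ccc(-c4ccccc4)cc3)nn2)=C(C)C1=O`, 4000 nM

Compound 2 stands at the highest number of the three. Its nearest neighbour is compound 1: a 3.8-fold higher number from compound 1 to compound 2 (0.58 log units; beyond the scatter). Within the data shown here, compound 3 sits furthest from it, with the lowest number in the set, but no single-change step links compound 3 to compound 2, so only the two values themselves can be compared.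

Compound 4, `O[C@H](COCCOC[C@@H](O)Cc1cn(-c2cncnc2)nn1)Cc1ccc(-c2ccccc2)cc1`, is not yet measured. It differs from compound 2 in one place: pyrimidin-5-yl in place of thiophen-2-yl on an aromatic nitrogen.

Among the measured compounds shown here, only one measured step touches the group on this aromatic nitrogen, the change from compound 1 to compound 2, and it moved the number upward by a modest amount. For the measured compounds named here, no measured pair exchanges one small aromatic ring for another at this position, so nothing shows whether pyrimidin-5-yl behaves more like thiophen-2-yl or like 4-cyanobenzyl. On this basis the expectation for compound 4 is a number close to that of compound 2, with any step most likely within the scatter: a 1.3-fold lower number from compound 2 to compound 4 (0.13 log units; within the scatter) is the estimated step. Compound 4 is therefore estimated at 25000 nM, with a range from 8000 nM to 80000 nM.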

Compound 4, concentration for 50% growth inhibition: > 100000 nM
Compound 4: a limit, no number; the forecaster's own chance of this, stated with the estimate: 10%; middle value at least 4.0-fold (0.60 log units) away from the limit.
By their numbers in this assay, from the lowest: compound 3; then compound 1; then compound 2. At a limit, above all of these: compound 4.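

In this assay, compound 4 gives no number, only a limit of the assay: the limit of > 100000 nM in this assay, at which 1 of the 4 values shown sits.

Among these compounds, exchanging one small aromatic ring for another on this aromatic nitrogen, a swap that no earlier pair covered, gives an at least 2.9-fold higher number from compound 2 to compound 4 (0.47 log units; beyond the scatter), so thiophen-2-yl and pyrimidin-5-yl are not interchangeable at this position. Set against the 4-cyanobenzyl group, the change gives an at least 11-fold higher number from compound 1 to compound 4 (1.05 log units; beyond the scatter), which places the three groups in the order 4-cyanobenzyl, thiophen-2-yl, pyrimidin-5-yl, with the true size of both new steps still open beyond what the limit allows.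

The compounds shown do not separate the two things that change together from compound 2 to compound 4, a five-membered ring with 1 hetero atom giving way to a six-membered ring with 2 hetero atoms, and they offer no measured property that would account for the loss. A plain phenyl ring and a pyridin-3-yl ring on this nitrogen would divide ring size from the number of ring nitrogens, and would show whether the second ring nitrogen of pyrimidin-5-yl carries the change.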